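A methoxy for trifluoromethyl exchange in an amide series

The source may report more compounds than this note shows. Statements on the series, on what has been measured and on what is new or still open speak of the compounds shown alone.

Compound 1 `COc1cc2oc(-c3cccc(NC(=O)c4ccc(Br)cc4)c3)cc(=O)c2c(OC)c1OC` gives 9650 nM
Compound 2 `COc1cc2oc(-c3cccc(NC(=O)c4ccc(F)cc4)c3)cc(=O)c2c(OC)c1OC` gives 14700 nM
Compound 3 `COc1cc2oc(-c3cccc(NC(=O)c4ccc(C(F)(F)F)cc4)c3)cc(=O)c2c(OC)c1OC` gives 10600 nM

In a functional assay on MCF7 cells (Homo sapiens) for inhibition, read by MTT assay (on this read-out lower numbers stand for stronger inhibition of growth and higher numbers for weaker inhibition of growth), compound 3 lies within the scatter of both other compounds (a 1.1-fold higher number from compound 1 to compound 3 (0.04 log units; within the scatter)) and (a 1.4-fold lower number from compound 2 to compound 3 (0.14 log units; within the scatter)). The change to compound 4 `COc1ccc(C(=O)Nc2cccc(-c3cc(=O)c4c(OC)c(OC)c(OC)cc4o3)c2)cc1` is methoxy in place of trifluoromethyl on an aromatic carbon, para to a large group (methoxy in place of trifluoromethyl on an aromatic carbon). Going by the values given here, no measured compound carries methoxy, so the only guide is the exchanges among bromo, fluoro and trifluoromethyl at that place, which include (a 1.5-fold higher number from compound 1 to compound 2 (0.18 log units; within the scatter)). All three stayed within the scatter. In this assay no step beyond the scatter is therefore expected, and the estimated step is small (a 1.1-fold higher number from compound 3 to compound 4 (0.04 log units; within the scatter)). Compound 4 is estimated at 11500 nM (expected range 5500 nM to 24000 nM).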

Compound 4, concentration for 50% growth inhibition: 6870 nM
Compound 4: middle estimate off by 1.7-fold (0.22 log units), on the high side, within the range that was stated.
By their numbers in this assay, from the lowest: compounds 4, 1, 3 and 2 (each within the scatter of the next, the first and the last beyond it).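

In this assay, going by these compounds alone, methoxy gives the only step at this place, on an aromatic carbon para to a large group, that lies beyond the scatter (a 2.1-fold lower number from compound 2 to compound 4 (0.33 log units; beyond the scatter)), and that step is modest. Against the other two groups methoxy stays within the scatter (a 1.5-fold lower number from compound 3 to compound 4 (0.19 log units; within the scatter); a 1.4-fold lower number from compound 1 to compound 4 (0.15 log units; within the scatter)), so it separates only from fluoro. Nothing shown here gives a reason for this step.

On these data alone, whether an amine or a hydroxyl at this place would move the number further remains open. So does whether a longer chain such as ethoxy would keep the step seen with methoxy.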